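A few compounds are considered here, and "the series" means these few. Any claim that something is new, unique, unknown or untested is made for them only; others in the source may bear on it.

The three measured compounds share one arrangement: a vinyl sulfone linking a pyridine ring to a chlorinated benzene ring, with a halogen on the pyridine. Compound 1 `O=S(=O)(/C=C/c1ncccc1F)c1ccccc1Cl` carries fluoro there, and in an assay on U2OS cells for activation of nuclear factor erythroid 2-related factor 2 (Homo sapiens), read by beta-arrestin recruitment, with a stated time of 6 h (on this read-out lower numbers stand for an effect already at smaller amounts and higher numbers for an effect only at larger amounts of compound), compound 1 gives 122 nM. Compound 2 `O=S(=O)(/C=C/c1ncccc1Cl)c1ccccc1Cl` differs from it by chloro in place of fluoro on an aromatic carbon, the place being on an aromatic carbon of a six-membered aromatic ring with one nitrogen, ortho to a large group and two atoms from the ring nitrogen; in this assay compound 2 gives 26 nM, a step of a 4.7-fold lower number from compound 1 to compound 2 (0.67 log units; beyond the scatter).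

Compound 3 `O=S(=O)(/C=C/c1ncccc1F)c1cccc(Cl)c1` has the same atoms as compound 1 joined differently; the difference between the two cores is not broken down here. In this assay compound 3 gives 198 nM, which lies within the scatter of compound 1 and is beyond the scatter from compound 2.

Compound 4 `O=S(=O)(/C=C/c1ncccc1Cl)c1cccc(Cl)c1` is built from compound 3 by chloro in place of fluoro on an aromatic carbon, at a place described in exactly the same words as for the earlier pair, so it is the same change. For the measured compounds named here, because compound 3 sits close to compound 1 in this assay with compound 1 at 122 nM and compound 3 at 198 nM, the step of a 4.7-fold lower number from compound 1 to compound 2 (0.67 log units; beyond the scatter) is the only guide, and a slightly smaller version of it is expected, giving a 4.0-fold lower number from compound 3 to compound 4 (0.60 log units; beyond the scatter). Compound 4 is therefore estimated at 50 nM in this assay, plausibly between 20 nM and 125 nM.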

Compound 4, half-maximal effective concentration: 46 nM
Beside the measured number, compound 4's estimate is 1.1-fold (0.04 log units) above it; low and high end bracket the measured number.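

Replacing fluoro with chloro on the six-membered aromatic ring with one nitrogen gives a 4.3-fold lower number from compound 3 to compound 4 (0.63 log units; beyond the scatter) in this assay, so the lower number seen on the core of compound 1 appears again on the core of compound 3. Placed side by side, the two steps cannot be told apart, which means that this change carries over between these two cores with its size intact: the same change on two cores in this assay, a 4.7-fold lower number (0.67 log units; beyond the scatter) from compound 1 to compound 2 and a 4.3-fold lower number (0.63 log units; beyond the scatter) from compound 3 to compound 4, 1.1-fold (0.04 log units) apart, within the scatter of two such steps This is still only one pair of cores with the same atoms joined differently, so the result does not show that the step would keep its size on a more different core, and it does not explain why chloro gives the lower number.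

The compounds shown have only fluoro or chloro at this place on the ring with one nitrogen, so it remains open whether a bromo, methyl or methoxy group there would give a number lower still or lose the gain. Going by these compounds, it is also open whether the step would keep its size if the chloro on the benzene ring gave way to a different group, such as an amine or a carboxylic acid.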